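Swapping One Ring Group for Another

The source may hold more compounds than are shown below. What is called first, only, known or untested is meant among the compounds shown, and "the series" means these compounds.

Of the compounds shown here, two have values so far. In a functional assay on HT-29 cells (Homo sapiens) for inhibition, read by sulforhodamine B assay, with a stated time of 48 h (a higher number here means a weaker inhibitor of growth, a lower number a stronger inhibitor of growth), compound 1 (`O=C(CCl)NC(=O)Nc1ccc2ccccc2c1`) gives 4900 nM and compound 2 (`O=C(CCl)NC(=O)Nc1ccc(C2CCCCC2)cc1`) gives 2300 nM as its result. Compound 2 therefore holds the lower of the two numbers, and its gap to compound 1 lies beyond the usual scatter, which makes it the stronger growth inhibitor of the pair.

Compound 3 (`O=C(CCl)NC(=O)Nc1ccc(OC2CCCC2)cc1`) has not yet been measured. It carries cyclopentyloxy in place of cyclohexyl on an aromatic carbon and is otherwise the same as compound 2. No change made at a single place has been measured yet, so the guide is thin. The two known values, from compounds that differ more widely, still lie fairly close together. In this assay no step beyond the scatter is therefore expected, with only a slight lean towards a higher number. The expected change is a 1.3-fold higher number from compound 2 to compound 3 (0.12 log units; within the scatter) and would stay within the scatter. For compound 3 the estimated value is 3000 nM with a likely range from 1300 nM to 7000 nM in this test.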

Compound 3, concentration for 50% growth inhibition: 3100 nM
Beside the measured number, compound 3's estimate is 1.0-fold (0.01 log units) below it; the measured number falls inside the stated range.
By their numbers in this assay, from the lowest: compounds 2, 3 and 1 (each within the scatter of the next, the first and the last beyond it).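

For the compounds shown here, this is the first change at a single place that can be read, and a 1.3-fold higher number from compound 2 to compound 3 (0.13 log units; within the scatter) in this assay shows that the two groups cannot be told apart in this test. On this aromatic carbon, cyclohexyl can thus give way to cyclopentyloxy, which swaps a six-membered ring for a five-membered one and adds an oxygen and one hydrogen-bond acceptor while keeping the same count of heavy atoms, and growth inhibition stays within the scatter. No accompanying measurement offers an explanation for this result.

The compounds shown leave open which part of the swap matters, since the ring size and the oxygen change together, and cyclopentyl or cyclohexyloxy on the same aromatic carbon would separate the two. They also leave open whether this aromatic carbon accepts groups of a quite different kind, such as an amine, a carboxylic acid or a longer open chain like hexyl, as readily as it accepts these two ring groups.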